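The source may report more compounds than this note shows. Statements on the series, on what has been measured and on what is new or still open speak of the compounds shown alone.

Compound 1 `N=C(N)NS(=O)(=O)c1ccc(N/C=C\C(=O)c2cc3ccccc3oc2=O)cc1` gives 87600 nM in a functional assay on T47D cells (Homo sapiens) for cytotoxicity, read by sulforhodamine B assay, with a stated time of 48 h; a higher number here means a weaker inhibitor, a lower number a stronger inhibitor.
Compound 2 `Cc1nnc(NS(=O)(=O)c2ccc(N/C=C\C(=O)c3cc4ccccc4oc3=O)cc2)s1` gives 94000 nM in this assay.
Compound 3 `Cc1ccnc(NS(=O)(=O)c2ccc(N/C=C\C(=O)c3cc4ccccc4oc3=O)cc2)n1` gives 24500 nM in this assay.

Of these three numbers, compound 3 has the lowest. Its nearest neighbour is compound 1, reached by a 3.6-fold lower number from compound 1 to compound 3 (0.55 log units; beyond the scatter), and the step of a 3.8-fold lower number from compound 2 to compound 3 (0.58 log units; beyond the scatter) is of the same order; both lie beyond the scatter, so compound 3 stands apart as the strongest of the three in this assay. Compound 4 `Cc1cc(C)nc(NS(=O)(=O)c2ccc(N/C=C\C(=O)c3cc4ccccc4oc3=O)cc2)n1` is the next compound, and it differs from compound 3 by methyl in place of hydrogen on an aromatic carbon.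

Going by the values given here, no measured step matches this change. The two steps that end at compound 3 exchange one whole group on the sulfonamide nitrogen for another, whereas here the ring of compound 3 is kept and a single methyl is added to it. The step of a 1.1-fold higher number from compound 1 to compound 2 (0.03 log units; within the scatter) further shows that even a larger exchange of group can leave the number within the scatter. A small change of this kind is therefore expected to give no step beyond the scatter, a 1.1-fold lower number from compound 3 to compound 4 (0.05 log units; within the scatter). For compound 4 the expected value in this assay is 22000 nM, with a range from 8000 nM to 60000 nM.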

Compound 4, half-maximal inhibitory concentration: 62200 nM
Compound 4: the middle estimate sits 2.8-fold (0.45 log units) below what was measured, and the stated range ends below it.
By their numbers in this assay, from the lowest: compound 3; then compounds 4, 1 and 2 (each within the scatter of the next).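

In this assay, going from 4-methylpyrimidin-2-yl to 4,6-dimethylpyrimidin-2-yl shows that one methyl on this aromatic carbon, next to the ring nitrogen, is enough to move the number beyond the scatter (a 2.5-fold higher number from compound 3 to compound 4 (0.40 log units; beyond the scatter)). The step also removes what set compound 3 apart, as compound 4 stays within the scatter of both other compounds (a 1.5-fold lower number from compound 2 to compound 4 (0.18 log units; within the scatter); a 1.4-fold lower number from compound 1 to compound 4 (0.15 log units; within the scatter)), so among these compounds the lowest number belongs to the 4-methylpyrimidin-2-yl group and not to any pyrimidine ring. No measurement given here accounts for this step.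

The compounds shown leave open whether other groups on this carbon, such as an ethyl chain, a methoxy group or an amine, would behave like the methyl. They also leave open where the unsubstituted pyrimidin-2-yl group would fall.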